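The source may hold more compounds than are shown below. What is called first, only, known or untested is meant among the compounds shown, and "the series" means these compounds.

Working notes on the series. Four compounds share a core: compound 1 `O=C(Nc1cc(-c2nc3ccccc3s2)ccc1Cl)c1cc([N+](=O)[O-])ccc1Cl`, compound 2 `Cc1ccc(-c2nc3ccccc3o2)cc1NC(=O)c1cc([N+](=O)[O-])ccc1Cl`, compound 3 `COc1cc(Cl)c(C(=O)Nc2cccc(-c3nc4ccccc4s3)c2)cc1[N+](=O)[O-]` and compound 4 `O=C(Nc1cccc(-c2nc3ccccc3s2)c1)c1cc([N+](=O)[O-])c(O)cc1Cl`. Three of them have been run in an ADME assay for permeability, using PAMPA, at pH 7.4; on this read-out higher numbers stand for higher permeability and lower numbers for lower permeability. In this assay compound 1 gives "below limit of detection" (no number reported), so no number is available for it. In this assay compound 2 likewise gives "below limit of detection" (no number reported), again without a number. In this assay, within the data shown here, compound 3 gives 12 10^-6 cm/s, and this is the only number so far; the other two entries supply nothing to set beside it. Among the measured compounds shown here, no two measured compounds differ in a single place, so no step between measured compounds can be drawn.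

Compound 4 differs from compound 3 in one place: hydrogen in place of methyl on an oxygen on an aromatic ring. For the measured compounds named here, the series holds no precedent for this change, and the expectation can rest only on compound 3. A small step downward is expected, a 1.7-fold lower number from compound 3 to compound 4 (0.23 log units; within the scatter), about at the edge of the usual scatter and possibly within it. Compound 4 in this assay is therefore estimated at 7 10^-6 cm/s, with a range from 2.5 10^-6 cm/s to 15 10^-6 cm/s. The estimate is anchored on compound 3 with its value of 12 10^-6 cm/s, and a result that again reports no number cannot be ruled out, given that two of three entries did so.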

Compound 4, apparent permeability: 307 10^-6 cm/s
Beside the measured number, compound 4's estimate is 44-fold (1.64 log units) below it; the measured number lies above the stated range.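

In this assay the change from methoxy to hydroxy, hydrogen in place of methyl on an oxygen on an aromatic ring, comes with a 26-fold higher number from compound 3 to compound 4 (1.41 log units; beyond the scatter) and so lies well beyond the usual scatter. Among these compounds, the earlier entries offered no step at all, so this pair is the first sign that this place on the shared core can move the read-out strongly, and that the hydroxy compound stands on the higher side; the finding rests on this single pair. No measurement shown bears on what lies behind a step of this size.

Still open, on these data alone, is whether the step belongs to the hydroxy group itself or holds more widely at this place, which an ethoxy group, an amine or a carboxylic acid there could help to settle. As far as these compounds go, compound 1 and compound 2 differ from compound 3 and compound 4 in more than one place, so whether the same change would carry the same weight on other versions of the core also remains open.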